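Varying the ring on a shared side-chain carbon

The compounds below may be only part of what the source reports. "The series", "measured", "known", "first", "only" and "open" are said of these compounds alone.

Three compounds built on one core differ only in the ring attached to a saturated chain carbon bound to an aromatic carbon and a saturated chain carbon. In an assay on CHO cells for displacement of a labelled ligand from prostaglandin E2 receptor EP3 subtype (Homo sapiens), read by radioligand binding (on this read-out lower numbers stand for stronger inhibition and higher numbers for weaker inhibition), compound 1 `CC(C)C(c1ccc(-c2ccc3cccc(F)c3c2)[nH]c1=O)N1CCCCS1(=O)=O` gives 14 nM. Compound 2 `CC(C)C(c1nnc[nH]1)c1ccc(-c2ccc3cccc(F)c3c2)[nH]c1=O` gives 12 nM in this assay, and compound 3 `CC(C)C(c1ccc(-c2ccc3cccc(F)c3c2)[nH]c1=O)N1CCNC1=O` gives 9.1 nM. The three numbers sit close together: the steps of a 1.2-fold lower number from compound 1 to compound 2 (0.07 log units; within the scatter), a 1.5-fold lower number from compound 1 to compound 3 (0.19 log units; within the scatter) and a 1.3-fold lower number from compound 2 to compound 3 (0.12 log units; within the scatter) all stay within the scatter, so compound 3 shows the lowest of the three numbers without standing apart from the other two.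

Compound 4 `CC(C)C(/C=C1/CCNC1=O)c1ccc(-c2ccc3cccc(F)c3c2)[nH]c1=O` is the next variation at the same place. Its change from compound 3 is a group of 7 heavy atoms (5 carbon, 1 nitrogen, 1 oxygen; one five-membered non-aromatic ring with 1 hetero atom) in place of a group of 6 heavy atoms (3 carbon, 2 nitrogen, 1 oxygen; one five-membered non-aromatic ring with 2 hetero atoms), on a saturated chain carbon bound to an aromatic carbon and a saturated chain carbon. The entering group carries one hydrogen-bond donor and one hydrogen-bond acceptor, as the leaving group did. Every measured exchange at this position, whether a six-membered non-aromatic ring, a five-membered aromatic ring or a five-membered non-aromatic ring, moved the number by less than the scatter, so no step beyond the scatter is expected in this assay here either. Compound 4 is therefore estimated at 10 nM, with a range from 4 nM to 25 nM, which is expected to amount to a step of a 1.1-fold higher number from compound 3 to compound 4 (0.04 log units; within the scatter).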

Compound 4, inhibition constant: 5.3 nM
Estimate against measurement, compound 4: 1.9-fold (0.28 log units) above, within the range that was stated.
By their numbers in this assay, from the lowest: compounds 4, 3, 2 and 1 (each within the scatter of the next, the first and the last beyond it).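

Among these compounds, this position now gives steps beyond the scatter for the first time in this assay: a 2.3-fold lower number from compound 2 to compound 4 (0.35 log units; beyond the scatter) and a 2.6-fold lower number from compound 1 to compound 4 (0.42 log units; beyond the scatter) are both modest, while every step among the first three compounds stayed within the scatter. The step closest in structure is a 1.7-fold lower number from compound 3 to compound 4 (0.23 log units; within the scatter), which leaves compound 3 and compound 4 indistinguishable in this assay, even though 2-oxoimidazolidin-1-yl gives way to a group with a second double bond outside aromatic rings and the same counts of hydrogen-bond donors and acceptors. So the new group separates from the triazole and the six-membered ring of the earlier compounds but not from the other five-membered non-aromatic ring, and nothing measured here offers an explanation for these differences.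

As far as these compounds go, it remains open whether the double bond that joins the new ring to the chain contributes at all, which a matching group with a single bond in its place could test. All four groups here are rings, so it is also unknown whether an open-chain amine or a carboxylic acid on the same saturated chain carbon would give a number in the same range.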